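The source may hold more compounds than are shown below. What is called first, only, known or untested is meant among the compounds shown, and "the series" means these compounds.

Working notes on the series. The shared core is carried by compound 1 `COc1cc2oc(/C=C/[S+](C)[O-])cc(=O)c2cc1O` and compound 2 `C[S+]([O-])/C=C/c1cc(=O)c2ccccc2o1`, which differ in the substitution of the fused ring of carbon only. In an ADME assay on WS1 cells (Homo sapiens) for inhibition, with a stated time of 48 h (on this read-out higher numbers stand for weaker inhibition and lower numbers for stronger inhibition), compound 1 gives only a limit of the assay, > 10000 nM, and no number. That limit is the point at which one of the two values sits (the limit of > 10000 nM in this assay, at which 1 of the 2 values shown sits). In this assay compound 2 gives 9000 nM, the only number shown in the set. The unmeasured compound 3 `C[S+]([O-])/C=C/c1cc(=O)c2cc(O)ccc2o1` is reached from compound 2 by a single change: hydroxy in place of hydrogen on an aromatic carbon. Among the compounds with values here, no step between measured compounds is available to size this change. The step from compound 2 to compound 3 is expected to be none beyond the scatter, no change at the digits printed from compound 2 to compound 3 (within the scatter), as compound 1, which also carries a hydroxy on that ring, gives only the limit > 10000 nM. Compound 3 is therefore estimated at 9000 nM, within 4000 nM to 20000 nM, with a fair chance that only a limit is reported.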

Compound 3, half-maximal inhibitory concentration: > 10000 nM
Compound 3: only a limit was reported; the forecaster's own chance of this, stated with the estimate: 40%; middle value at least 1.1-fold (0.04 log units) from the limit.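

In this assay, hydroxy in place of hydrogen on an aromatic carbon gives an at least 1.1-fold higher number from compound 2 to compound 3 (0.04 log units; that floor lies within the scatter), so the change is bounded from one side only and nothing beyond the scatter is shown. Compound 3 gives > 10000 nM, a limit and not a number, which places a single hydroxy at this position, meta to a fused ring and para to a fused ring, at the end of the read-out. The step between compound 1 and compound 3 cannot be read, and the set now crowds at that end: the limit of > 10000 nM in this assay, at which 2 of the 3 values shown sit.

On these data alone, the true size of the hydroxy step stays open, and so does whether it passes the scatter. The compounds shown do not tell how an amine or a carboxylic acid on the same aromatic carbon would compare with compound 2.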